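The source may report more compounds than this note shows. Statements on the series, on what has been measured and on what is new or still open speak of the compounds shown alone.

In a functional assay on HCT-116 cells (Homo sapiens) for cytotoxicity, read by MTT assay, with a stated time of 48 h, in the presence of a further agent that is not named here (a lower number here means that less compound is needed, a higher number that more compound is needed for the effect), compound 1 `COc1ccc(-c2cc(NNC(=O)Nc3cc(Cl)nc(OC(C)C)c3)nc3c2cnn3C)cc1` gives 39800 nM as its value, the highest number of the three measured compounds. Compound 2 `Cn1ncc2c(-c3ccccc3)cc(NNC(=O)Nc3cc(Cl)nc(Cl)c3)nc21` gives 6240 nM and compound 3 `Cn1ncc2c(-c3ccc(F)cc3)cc(NNC(=O)Nc3cc(Cl)nc(Cl)c3)nc21` gives 8210 nM as theirs, both clearly lower numbers than that of compound 1. These two differ from compound 1 in more than one place, so their gaps to it cannot be tied to any single group.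

Compound 4 `CCCOc1cc(NC(=O)NNc2cc(-c3ccc(OC)cc3)c3cnn(C)c3n2)cc(Cl)n1` is not yet measured. It keeps the same atoms as compound 1, joined differently, with propyl in place of isopropyl on an oxygen on an aromatic ring as the whole change: propyl in place of isopropyl on an oxygen on an aromatic ring.

Among the compounds with values here, the only measured single change is a 1.3-fold higher number from compound 2 to compound 3 (0.12 log units; within the scatter) and it stays within the scatter. Within the data shown here, it is a fluoro in place of hydrogen on an aromatic carbon, so it bears only loosely on this change, and no measured pair alters the group on that oxygen. With so little to go on, in this assay no shift beyond the scatter is expected. The expected step is a 1.2-fold lower number from compound 1 to compound 4 (0.09 log units; within the scatter) and the uncertainty around it is wide. For compound 4 the estimate is 32000 nM with an expected range of 13000 nM to 80000 nM overall.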

Compound 4, half-maximal effective concentration: 33300 nM
Estimate against measurement, compound 4: 1.0-fold (0.02 log units) below; measured number inside the range.
By their numbers in this assay, from the lowest: compounds 2 and 3 (each within the scatter of the next); then compounds 4 and 1 (each within the scatter of the next).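

In this assay, within the data shown here, replacing isopropyl with propyl on the oxygen gives a 1.2-fold lower number from compound 1 to compound 4 (0.08 log units; within the scatter) and is the first measured change to the group at this position. Compound 1 and compound 4 carry the same three carbons there, joined differently, and this rearrangement leaves their numbers indistinguishable in this one core. The result therefore shows that this assay does not separate isopropoxy from propoxy here, although it cannot say how much the group on the oxygen matters overall. No supporting measurement is available to explain why the two chains read alike. A longer chain such as hexyl on the oxygen, or an amine in place of the whole isopropoxy group, remains untested among the compounds shown. As far as these compounds go, whether either would shift the number beyond the scatter stays open.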